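Tolerated Concentration From Compound 3 to Compound 4

A few compounds are considered here, and "the series" means these few. Any claim that something is new, unique, unknown or untested is made for them only; others in the source may bear on it.

Measured in an ADME assay on A549 cells (Homo sapiens) for cytotoxicity, read by resazurin assay, with a stated time of 48 h; a lower number here means that less compound is tolerated, a higher number that more compound is tolerated:
compound 1 `CC(C)CNc1ccc(NC(=O)c2cc(Cl)ccc2O)c(Cl)c1` gives 60000 nM
compound 2 `CC1(Nc2ccc(NC(=O)c3cc(Cl)ccc3O)c(Cl)c2)CCCC1` gives 157000 nM
compound 3 `O=C(Nc1ccc(NCc2ccncc2)cc1Cl)c1cc(Cl)ccc1O` gives 65300 nM

Compound 3 stands second highest of the three in this assay; compound 1 is nearest, within the scatter, and compound 2 furthest, the step of a 2.4-fold lower number from compound 2 to compound 3 (0.38 log units; beyond the scatter) lying beyond it. Compound 4 `O=C(Nc1ccc(NCCCO)cc1Cl)c1cc(Cl)ccc1O` differs from compound 3 by 2-hydroxyethyl in place of pyridin-4-yl on a saturated chain carbon bound to a nitrogen on an aromatic ring. Within the data shown here, the only step at the same place, a 1.1-fold higher number from compound 1 to compound 3 (0.04 log units; within the scatter), stayed within the scatter, while a 2.6-fold higher number from compound 1 to compound 2 (0.42 log units; beyond the scatter) and a 2.4-fold lower number from compound 2 to compound 3 (0.38 log units; beyond the scatter) were modest and concern a different group. Among the measured compounds shown here, no measured step involves the entering 2-hydroxyethyl. Compound 4 is therefore expected to give 65000 nM, with a range of 30000 nM to 140000 nM. This estimate means a step of a 1.0-fold lower number from compound 3 to compound 4 (0.00 log units; within the scatter), expected to remain within the scatter.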

Compound 4, half-maximal cytotoxic concentration: 106000 nM
The estimate for compound 4 lay 1.6-fold (0.21 log units) below the measured number; the measured number falls inside the stated range.
By their numbers in this assay, from the lowest: compounds 1, 3, 4 and 2 (each within the scatter of the next, the first and the last beyond it).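

In this assay, the ring-free 2-hydroxyethyl in place of pyridin-4-yl gives a 1.6-fold higher number from compound 3 to compound 4 (0.21 log units; within the scatter), so at this place, on a saturated chain carbon bound to a nitrogen on an aromatic ring, a group with no ring stays level with one that has an aromatic ring. The other two comparisons, a 1.8-fold higher number from compound 1 to compound 4 (0.25 log units; within the scatter) and a 1.5-fold lower number from compound 2 to compound 4 (0.17 log units; within the scatter), also stay within the scatter, although compound 1 and compound 2 lie beyond it from each other. No evidence on why these numbers stand where they do is available. The compounds shown leave open whether an amine or a carboxylic acid in place of 2-hydroxyethyl would stay in this range.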